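The source may hold more compounds than are shown below. What is called first, only, known or untested is meant among the compounds shown, and "the series" means these compounds.

For the measured compounds named here, compound 2 `Cc1cccc(-c2cn3ccnc3c(-c3ccc4ncn(Cc5ccccc5)c4c3)n2)c1` gives 22.1% in a functional assay on A498 cells (Homo sapiens) for inhibition, read by sulforhodamine B assay, with a stated time of 48 h, tested at 10 uM (on this read-out higher numbers stand for more inhibition at the one concentration tested (going by the name of the read-out) and lower numbers for less inhibition), and stands higher of the two numbers known so far; compound 1 `O=Cc1ccc(-c2cn3ccnc3c(-c3ccc4ncn(C5CCCCC5)c4c3)n2)cc1` gives 11.2% in this assay, a gap beyond the usual scatter. Compound 3 `O=Cc1ccc(-c2cn3ccnc3c(-c3ccc4ncn(Cc5ccccc5)c4c3)n2)cc1` has not yet been measured. It differs from compound 2 in one place: 4-formylphenyl in place of 3-methylphenyl on an aromatic carbon. A modest downward step is expected, a number 8.1 percentage points lower from compound 2 to compound 3 (within the scatter), because compound 1 carries the same 4-formylphenyl group and gives 11.2%. Compound 3 is therefore estimated to reach 14% in this assay, with a likely range from 3% to 28%.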

Compound 3, a percentage reported as inhibition, at one concentration (the size of the read-out at that concentration, not a potency): 11.2%
Beside the measured number, compound 3's estimate is 2.8 percentage points above it, within the range that was stated.
By their numbers in this assay, from the lowest: compounds 1 and 3 (each within the scatter of the next); then compound 2.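

In this assay the change from 3-methylphenyl to 4-formylphenyl on the aromatic carbon now has a direct comparison, and it lowers the read-out beyond the scatter (a number 10.9 percentage points lower from compound 2 to compound 3 (beyond the scatter)). With 4-formylphenyl held in place, benzyl instead of cyclohexyl on the aromatic nitrogen makes no visible difference (no change at the digits printed from compound 1 to compound 3 (within the scatter)). Nothing available explains the drop seen with 4-formylphenyl. From the compounds shown here alone, whether an amine or a carboxylic acid on the phenyl ring at this aromatic carbon would read differently stays open, as does whether 3-methylphenyl would give the same number with cyclohexyl on the nitrogen.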